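A few compounds are considered here, and "the series" means these few. Any claim that something is new, unique, unknown or untested is made for them only; others in the source may bear on it.

Measured in a functional assay on MCF7 cells (Homo sapiens) for cytotoxicity, read by MTT assay, with a stated time of 72 h; on this read-out higher numbers stand for weaker inhibition and lower numbers for stronger inhibition:
- Compound 1 `CCc1ccc(-c2cc(C(=O)Nc3ccc(Oc4ccnc(C(=O)NC)c4)c(F)c3)ncn2)cc1`: 7630 nM
- Compound 2 `CNC(=O)c1cc(Oc2ccc(NC(=O)c3cc(-c4ccccc4)ncn3)cc2F)ccn1`: 32400 nM

Compound 2 holds the higher of these two numbers, so it is the weaker inhibitor in this assay. Compound 3 `CNC(=O)c1cc(Oc2ccc(NC(=O)c3cc(-c4ccc(OC)cc4)ncn3)cc2F)ccn1` carries methoxy in place of hydrogen on an aromatic carbon, para to a large group: methoxy in place of hydrogen on an aromatic carbon.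

Among the measured compounds shown here, one measured step bears on this change: a 4.2-fold higher number from compound 1 to compound 2 (0.63 log units; beyond the scatter). It is a modest step, with hydrogen in place of ethyl on an aromatic carbon. Read in reverse, it suggests that a group entering on that ring could lower the number. However, it is a single pair, and no measured compound carries methoxy, so the expected step is similar in size or smaller. The expected change is a 2.2-fold lower number from compound 2 to compound 3 (0.33 log units; beyond the scatter). For compound 3 the estimated value is 15000 nM, with an expected range of 5000 nM to 40000 nM.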

Compound 3, half-maximal inhibitory concentration: 46200 nM
Compound 3: middle estimate off by 3.1-fold (0.49 log units), on the low side, and the stated range ends below it.
By their numbers in this assay, from the lowest: compound 1; then compounds 2 and 3 (each within the scatter of the next).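

In this assay, the change from phenyl to 4-methoxyphenyl gives a 1.4-fold higher number from compound 2 to compound 3 (0.15 log units; within the scatter) and so does not separate the two compounds, which means that a group entering at this place does not by itself lower the number. Ethyl and methoxy at the same place do separate, with a 6.1-fold higher number from compound 1 to compound 3 (0.78 log units; beyond the scatter), so the gain read from the earlier step holds for ethyl and does not extend to methoxy. Nothing on hand explains this difference between the two groups.

Going by these compounds, whether a longer chain such as propyl, or a chlorine atom or an amine, at this place would track ethyl or methoxy stays open. With only ethyl and methoxy to compare against hydrogen, no rule for this position can yet be drawn.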